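Piperazine amide series: notes before compound 4

A few compounds are considered here, and "the series" means these few. Any claim that something is new, unique, unknown or untested is made for them only; others in the source may bear on it.

The three measured compounds share one core and differ only in the group on a saturated chain carbon bound to a carbonyl carbon. Compound 1 `Cc1ccc2oc(SCC(=O)Nc3ccc(-c4nc(-c5ccccc5)c(-c5ccccc5)n4C)cc3)nc2c1` gives 11% in a functional assay on HT-29 cells (Homo sapiens) for cytotoxicity, read by MTT assay, with a stated time of 24 h, tested at 0.64 ug/mL; on this read-out higher numbers stand for a stronger effect at the one concentration tested and lower numbers for a weaker effect. Compound 2 `CN1CCN(CC(=O)Nc2ccc(-c3nc(-c4ccccc4)c(-c4ccccc4)n3C)cc2)CC1` gives 18.8% in this assay, and compound 3 `CCN1CCN(CC(=O)Nc2ccc(-c3nc(-c4ccccc4)c(-c4ccccc4)n3C)cc2)CC1` gives 7.4% in this assay. Compound 3 holds the lowest of the three numbers; its nearest neighbour is compound 1, with a number 3.6 percentage points lower from compound 1 to compound 3 (within the scatter), and its furthest is compound 2, with a number 11.4 percentage points lower from compound 2 to compound 3 (beyond the scatter). Compound 4 `CN(C)/C=C/N1CCN(CC(=O)Nc2ccc(-c3nc(-c4ccccc4)c(-c4ccccc4)n3C)cc2)CC1` differs from compound 3 only on the amine nitrogen in a ring: 2-(dimethylamino)ethenyl in place of ethyl on an amine nitrogen in a ring. Among the measured compounds shown here, the steps that bear on this position are a number 7.8 percentage points higher from compound 1 to compound 2 (within the scatter), a number 3.6 percentage points lower from compound 1 to compound 3 (within the scatter) and a number 11.4 percentage points lower from compound 2 to compound 3 (beyond the scatter); together they show that changes here have moved this assay little, with only one of them beyond the scatter. No step beyond the scatter is therefore expected for compound 4, and the estimated step is a number 2.6 percentage points higher from compound 3 to compound 4 (within the scatter). Compound 4 is expected to give 10% in this assay, within a range of 2% to 22%.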

Compound 4, a percentage reported as activity, at one concentration (the size of the read-out at that concentration, not a potency): 3.1%
Compound 4: middle estimate off by 6.9 percentage points, on the high side; low and high end bracket the measured number.
By their numbers in this assay, from the lowest: compounds 4, 3, 1 and 2 (each within the scatter of the next, the first and the last beyond it).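

Notes after compound 4: in this assay the change from ethyl to 2-(dimethylamino)ethenyl on the amine nitrogen in a ring gives a number 4.3 percentage points lower from compound 3 to compound 4 (within the scatter) and so does not separate this larger, nitrogen-bearing group from ethyl. Against the methyl group the same substituent gives a number 15.7 percentage points lower from compound 2 to compound 4 (beyond the scatter) and thus a second step beyond the scatter at this nitrogen, so compound 2 now stands apart from both compound 3 and compound 4, though not from compound 1. The exchange of the whole (5-methyl-1,3-benzoxazol-2-yl)sulfanyl group gives a number 7.9 percentage points lower from compound 1 to compound 4 (within the scatter) and adds no separation from compound 1.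

On these data alone, whether the methyl result extends to a piperazine with a hydrogen or an acetyl group on this nitrogen remains open. No measurement shown here accounts for these steps.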